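Cyanomethyl on the Ring Nitrogen: Compound 3 to Compound 4

The source may hold more compounds than are shown below. What is called first, only, known or untested is meant among the compounds shown, and "the series" means these compounds.

Compound 1, `COc1cc(OC)c2cc(-c3ccccc3)c(O)nc2c1`: 10000 nM
Compound 2, `COc1ccc(-c2cc3cccc(OC)c3nc2O)cc1`: 10000 nM
Compound 3, `COc1ccc(-c2cc3c(OC)cc(OC)cc3n(C)c2=O)cc1`: 10000 nM

Of the compounds shown here, three have been measured in a functional assay on HCT-15 cells (Homo sapiens) for cytotoxicity, read by colorimetric assay and MTT assay; on this read-out lower numbers stand for stronger inhibition and higher numbers for weaker inhibition. Compound 1 gives 10000 nM, compound 2 gives 10000 nM and compound 3 gives 10000 nM. On these numbers compound 3 stands level with compound 1 and compound 2; the three values coincide at the digits shown, and none of the three can be set apart from the others within the scatter of this assay.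

The next compound, compound 4, `COc1ccc(-c2cc3c(OC)cc(OC)cc3n(CC#N)c2=O)cc1`, has not yet been measured. It differs from compound 3 in a single place: cyano in place of hydrogen on a saturated chain carbon bound to an aromatic nitrogen. For the measured compounds named here, no step between measured compounds that differ in only one place is available, so there is nothing in the measured set that directly shows what such a change does here.

Given that compound 1, compound 2 and compound 3 all share the same value, the step from compound 3 to compound 4 is expected to be small, with no direction that would go beyond the scatter, that is, a step of no change at the digits printed from compound 3 to compound 4 (within the scatter). Accordingly, compound 4 is estimated at 10000 nM in this assay, with a range from 5000 nM to 20000 nM.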

Compound 4, half-maximal inhibitory concentration: 10000 nM
Beside the measured number, compound 4's estimate shows no gap at the digits printed; the range from low to high includes it.
By their numbers in this assay, from the lowest: compounds 1, 2, 3 and 4 (each within the scatter of the next).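

Cyano in place of hydrogen on a saturated chain carbon bound to an aromatic nitrogen now provides the only step between compounds that differ in one place, and in this assay that step reads no change at the digits printed from compound 3 to compound 4 (within the scatter). Going from methyl to cyanomethyl at this position therefore leaves the value of compound 4 at 10000 nM, level with the three earlier compounds, so this position tolerates the change without any shift that can be told from the scatter in this assay. No other measurement bears on why the value stays where it is.

Going by these compounds, with all four compounds level, the set holds no reference with stronger inhibition against which this change could be read, so it remains open whether the same cyano group would leave the value in place on a compound that starts lower. On these data alone, it is also open whether a longer chain, an amine or a carboxylic acid on this saturated chain carbon would move the value in either direction.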